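A few compounds are considered here, and "the series" means these few. Any claim that something is new, unique, unknown or untested is made for them only; others in the source may bear on it.

Compound 1 `COc1cc2oc(-c3ccccc3)cc(=O)c2c(O)c1OCCCCN1CCN(C)CC1` gives 53500 nM in a functional assay on BCG823 cells (Homo sapiens) for antiproliferative activity, read by MTT assay, with a stated time of 48 h; on this read-out lower numbers stand for stronger inhibition and higher numbers for weaker inhibition. Going by the values given here, compound 2 `CCN(CC)CCCCOc1c(OC)cc2oc(-c3ccccc3)cc(=O)c2c1O` gives 17400 nM in this assay, the lowest of the two numbers so far, reached through a 3.1-fold lower number from compound 1 to compound 2 (0.49 log units; beyond the scatter). Compound 3 `COc1cc2oc(-c3ccccc3)cc(=O)c2c(O)c1OCCCCN1CCCCC1` carries piperidin-1-yl in place of diethylamino on a saturated chain carbon, four bonds along the chain from an oxygen on an aromatic ring. Among the compounds with values here, the only measured step that bears on this change is that amine exchange, and it was modest in size. A second exchange of one amine for another of similar kind is therefore expected to move this assay little, and the expected step is a 1.2-fold lower number from compound 2 to compound 3 (0.06 log units; within the scatter), within the scatter. Compound 3 is estimated at 15000 nM, with a range from 6000 nM to 40000 nM.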

Compound 3, half-maximal inhibitory concentration: 21900 nM
For compound 3 the middle estimate is 1.5-fold (0.16 log units) below the measured one; low and high end bracket the measured number.
By their numbers in this assay, from the lowest: compounds 2 and 3 (each within the scatter of the next); then compound 1.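

In this assay, closing the diethylamino group into piperidin-1-yl on the same chain leaves the number within the scatter (a 1.3-fold higher number from compound 2 to compound 3 (0.10 log units; within the scatter)), so these two amines are not told apart here. Piperidin-1-yl in place of 4-methylpiperazin-1-yl gives a step beyond the scatter (a 2.4-fold lower number from compound 1 to compound 3 (0.39 log units; beyond the scatter)), so among these three compounds, compound 1 alone stands apart at the higher number. No available data explain this difference. Morpholin-4-yl and pyrrolidin-1-yl at the same place remain open, as does a shorter or longer chain carrying these amines.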